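The source may hold more compounds than are shown below. What is called first, only, known or untested is meant among the compounds shown, and "the series" means these compounds.

Compound 1 `O=C(O)c1csc(-n2nc(-c3ccccc3)c3c2CCCC3)n1`: 16 nM in an assay on isolated protein for antagonist activity at prostaglandin E2 receptor EP1 subtype (Homo sapiens), read by reporter gene assay; a higher number here means a weaker inhibitor, a lower number a stronger inhibitor
Compound 2 `Nc1ccc2c(-c3ccccc3)nn(-c3nc(C(=O)O)cs3)c2c1`: 19 nM in this assay
Compound 3 `O=C(O)c1csc(-n2nc(-c3ccc(F)cc3)c3ccccc32)n1`: 4.5 nM in this assay

Among these three, compound 3 shows the lowest number in this assay; the gaps to compound 1 and to compound 2 both lie beyond the scatter, so compound 3 counts as the strongest inhibitor of the set. Compound 4 `O=C(O)c1csc(-n2nc(-c3cncnc3)c3ccccc32)n1` differs from compound 3 in one place: pyrimidin-5-yl in place of 4-fluorophenyl on an aromatic carbon. Going by the values given here, no measured pair isolates such a change, so the expectation rests on analogy alone. The step from compound 3 to compound 4 is expected to be a modest rise in the number, possibly within the scatter, estimated as a 2.7-fold higher number from compound 3 to compound 4 (0.43 log units; beyond the scatter). For compound 4 the value in this assay is estimated at 12 nM, with a range from 3 nM to 50 nM.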

Compound 4, half-maximal inhibitory concentration: > 100 nM
Compound 4 was reported as a limit; the forecaster's own chance of this, stated with the estimate: 3%; middle value at least 8.3-fold (0.92 log units) from the limit.
By their numbers in this assay, from the lowest: compound 3; then compounds 1 and 2 (each within the scatter of the next). At a limit, above all of these: compound 4.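

Pyrimidin-5-yl in place of 4-fluorophenyl on this aromatic carbon gives an at least 22-fold higher number from compound 3 to compound 4 (1.34 log units; beyond the scatter), the first step in the set that can be read at this position. Compounds 1, 2 and 3 all carry a carbon-only aromatic ring here, so only compound 4 shows that not every six-membered aromatic ring is accepted at this place. The reading for compound 4 in this assay is a limit, not a number: the limit of > 100 nM in this assay, at which 1 of the 4 values shown sits.

The compounds shown leave open whether pyridin-3-yl, with one ring nitrogen, or plain phenyl on the core of compound 3 would keep the number low. They also leave open whether the loss of the fluorine or the entry of the ring nitrogens accounts for the step.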